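This account rests on a few compounds, and the source may have more. Where it says the series, first, only, none or still open, it means among the compounds named here.

Compound 1 `CC(C)(C)c1ccc(Cn2cc(CN3C(=O)COc4ccccc43)nn2)cc1`: 25100 nM
Compound 2 `COc1ccc(Cn2cc(CN3C(=O)COc4ccccc43)nn2)cc1`: 18500 nM
Compound 3 `O=C1COc2ccccc2N1Cc1cn(Cc2ccc([N+](=O)[O-])cc2)nn1`: 15600 nM

All three were measured in a functional assay on HT-29 cells (Homo sapiens) for cytotoxicity, read by MTT assay, with a stated time of 6 days (a higher number here means a weaker inhibitor, a lower number a stronger inhibitor), and compound 3 stands within the scatter of both others. The measured steps are a 1.2-fold lower number from compound 2 to compound 3 (0.07 log units; within the scatter) and a 1.6-fold lower number from compound 1 to compound 3 (0.21 log units; within the scatter) and also a 1.4-fold lower number from compound 1 to compound 2 (0.13 log units; within the scatter) (each a swap on an aromatic carbon). Compound 4 `O=C1COc2ccccc2N1Cc1cn(C/C=C/c2ccccc2)nn1` brings a different change, 2-phenylethenyl in place of 4-nitrophenyl on a saturated chain carbon bound to an aromatic nitrogen. Among the measured compounds shown here, no measured step makes this exchange, so those steps bear on it only indirectly, and no step beyond the scatter is expected, in either direction. The expected change is a 1.2-fold higher number from compound 3 to compound 4 (0.06 log units; within the scatter) (an estimate only). Compound 4 is expected near 18000 nM (estimated range 8000 nM to 40000 nM).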

Compound 4, half-maximal inhibitory concentration: > 100000 nM
Compound 4 ended at the assay's limit; the forecaster's own chance of this, stated with the estimate: 10%; middle value at least 5.5-fold (0.74 log units) from the limit.
By their numbers in this assay, from the lowest: compounds 3, 2 and 1 (each within the scatter of the next). At a limit, above all of these: compound 4.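

Swaps on an aromatic carbon had stayed within the scatter, but the change on a saturated chain carbon bound to an aromatic nitrogen does not: this assay gives an at least 6.4-fold higher number from compound 3 to compound 4 (0.80 log units; beyond the scatter) and an at least 5.4-fold higher number from compound 2 to compound 4 (0.73 log units; beyond the scatter). This position therefore responds to 2-phenylethenyl, even though the group that leaves and the group that enters each carry one six-membered aromatic ring. Compound 4 stands at a limit, not at a number: the limit of > 100000 nM in this assay, at which 1 of the 4 values shown sits.

As far as these compounds go, it remains open how far compound 4 lies past that limit. From the compounds shown here alone, it is also open whether a saturated phenylpropyl chain or an unsubstituted benzyl group at this place would stay with compounds 1, 2 and 3 or move with compound 4.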